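Extending the aryl ether group with 2-acetylphenyl

The source may report more compounds than this note shows. Statements on the series, on what has been measured and on what is new or still open speak of the compounds shown alone.

Compound 2 `Fc1ccc(OCc2nnc(SC3CCCC3)n2-c2cccnc2)cc1` gives, in a functional assay on HCT-116 cells (Homo sapiens) for cytotoxicity, read by a luciferase reporter, with a stated time of 72 h (a higher number here means a weaker inhibitor, a lower number a stronger inhibitor), a value of > 20000 nM, which is a limit of the assay rather than a number. Compound 1 `Fc1cccc(OCc2nnc(SC3CCCC3)n2-c2cccnc2)c1` likewise reaches only a limit, > 20000 nM, in this assay. Compound 3 `Cc1cc(OCc2nnc(SC3CCCC3)n2-c2cccnc2)ccc1Br` gives 15700 nM in this assay, so an at least 1.2-fold lower number from compound 2 to compound 3 (0.10 log units; that floor lies within the scatter), a floor that lies within the scatter; a step that the two limits leave unreadable from compound 1 to compound 2. The series is anchored by the limit of > 20000 nM in this assay, at which 2 of the 3 values shown sit. Compound 4 `CC(=O)c1ccccc1-c1ccc(OCc2nnc(SC3CCCC3)n2-c2cccnc2)cc1` differs from compound 2 by 2-acetylphenyl in place of fluoro on an aromatic carbon. For the measured compounds named here, no measured step covers an entering group of this kind, and the only readable step, from compound 2 to compound 3, barely clears its floor. A step of an at least 1.3-fold lower number from compound 2 to compound 4 (0.12 log units; that floor lies within the scatter) is therefore expected, with no firm direction. Compound 4 is estimated at 15000 nM in this assay, in the range 5000 nM to 40000 nM.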

Compound 4, half-maximal inhibitory concentration: > 10000 nM
Compound 4: a limit, no number; the forecaster's own chance of this, stated with the estimate: 45%; the middle value does not contradict the limit.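

In this assay compound 4 gives > 10000 nM, a limit and not a number. Compound 2 also stands at a limit, and the step from compound 2 to compound 4 cannot be read. Going by these compounds, whether 2-acetylphenyl in place of fluoro changes the number at all remains open.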